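Methoxy in Place of Hydrogen: Expectation for Compound 4

The compounds below may be only part of what the source reports. "The series", "measured", "known", "first", "only" and "open" are said of these compounds alone.

Compound 1 `CC(C)(CNC(=O)c1ccc2ccccc2c1O)CC1=C(O)C(=O)c2ccccc2C1=O` gives 79500 nM in a functional assay on MCF7 cells (Homo sapiens) for cytotoxicity, read by resazurin assay, with a stated time of 3 days; a lower number here means a stronger inhibitor, a higher number a weaker inhibitor.
Compound 2 `COC1=C(CC(C)(C)CNC(=O)c2ccccc2)C(=O)c2ccccc2C1=O` gives 61800 nM in this assay.
Compound 3 `COC1=C(CC(C)(C)CNC(=O)c2ccccc2OC)C(=O)c2ccccc2C1=O` gives 70700 nM in this assay.

Compound 3 differs from compound 2 by methoxy in place of hydrogen on an aromatic carbon, and the step of a 1.1-fold higher number from compound 2 to compound 3 (0.06 log units; within the scatter). The difference between the core of compound 1 and the core of compound 2 is not broken down here. Compound 4 `COc1cc(C(=O)NCC(C)(C)CC2=C(O)C(=O)c3ccccc3C2=O)c(O)c2ccccc12` has not yet been measured; it differs from compound 1 by methoxy in place of hydrogen on an aromatic carbon. This is the same kind of change as that from compound 2 to compound 3, but the surroundings differ: in compound 3 the methoxy sits ortho to a large group on a six-membered aromatic ring of carbon only, whereas in compound 4 it sits on a ring that is part of a fused or bridged system of two rings, ortho to a fused ring, meta to a fused ring, meta to a large group and para to a hydroxy group. Because the comparable step a 1.1-fold higher number from compound 2 to compound 3 (0.06 log units; within the scatter) lay within the scatter, compound 4 is expected to show a step of a 1.1-fold higher number from compound 1 to compound 4 (0.03 log units; within the scatter). Compound 4 is therefore estimated at 85000 nM in this assay, most likely between 40000 nM and 180000 nM.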

Compound 4, half-maximal inhibitory concentration: 35600 nM
Estimate against measurement, compound 4: 2.4-fold (0.38 log units) above; the measured number lies below the stated range.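

In this assay methoxy in place of hydrogen on an aromatic carbon gives a 2.2-fold lower number from compound 1 to compound 4 (0.35 log units; beyond the scatter) on the core of compound 1, a modest step. Set beside the step seen for the same change on the core of compound 2, it does not separate from it: the same change on two cores in this assay, a 1.1-fold higher number (0.06 log units; within the scatter) from compound 2 to compound 3 and a 2.2-fold lower number (0.35 log units; beyond the scatter) from compound 1 to compound 4, 2.6-fold (0.41 log units) apart, within the scatter of two such steps. Among these compounds, the series therefore shows no firm difference between the two cores for this change, but with only one pair on each core it does not show that the change carries over unaltered either.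

The compounds shown leave open what an amine, a carboxylic acid or a longer chain would do in place of the methoxy. Also open, from the compounds shown here alone, is how methoxy would behave elsewhere on either core.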